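The source may hold more compounds than are shown below. What is called first, only, known or untested is meant among the compounds shown, and "the series" means these compounds.

Measured so far in a functional assay on BXPC-3 cells (Homo sapiens) for antiproliferative activity, read by sulforhodamine B assay, with a stated time of 72 h; on this read-out lower numbers stand for stronger inhibition and higher numbers for weaker inhibition
compound 1 `CC(C)(C)c1[nH]cnc1/C=c1\[nH]c(=O)/c(=C/c2cccc(C(=O)c3ccccc3)c2)[nH]c1=O` gives 0.63 nM
compound 2 `CC(C)(C)c1[nH]cnc1/C=c1\[nH]c(=O)/c(=C/c2cccc(C(=O)c3cccnc3)c2)[nH]c1=O` gives 4.05 nM
compound 3 `CC(C)(C)c1[nH]cnc1/C=c1\[nH]c(=O)/c(=C/c2cccc(C(=O)c3ccco3)c2)[nH]c1=O` gives 9.23 nM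

Compound 3 has the highest number of the three, and so the weakest inhibition. The value closest to it belongs to compound 2 (4.05 nM). Compound 4 `CC(C)(C)c1[nH]cnc1/C=c1\[nH]c(=O)/c(=C/c2cccc(C(=O)c3cc[nH]c3)c2)[nH]c1=O` has not yet been measured. The change leading to it is 1H-pyrrol-3-yl in place of furan-2-yl on a carbonyl carbon and puts 1H-pyrrol-3-yl in place of furan-2-yl on a carbonyl carbon.

Three measured steps alter the group at this same place. The large one is a 15-fold higher number from compound 1 to compound 3 (1.17 log units; beyond the scatter) and the modest ones are a 6.4-fold higher number from compound 1 to compound 2 (0.81 log units; beyond the scatter) and a 2.3-fold higher number from compound 2 to compound 3 (0.36 log units; beyond the scatter). None of them exchanges one five-membered aromatic ring for another, so the evidence is indirect. The ring count stays the same here, and the smallest measured step, between compound 2 and compound 3 (a 2.3-fold higher number from compound 2 to compound 3 (0.36 log units; beyond the scatter)), is only modest. A change beyond the scatter in this assay is therefore not expected, in either direction.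

The expected value for compound 4 is 8 nM, with an estimated range from 2.5 nM to 25 nM.
The estimate therefore means an expected step of a 1.2-fold lower number from compound 3 to compound 4 (0.06 log units; within the scatter).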

Compound 4, half-maximal inhibitory concentration: > 100 nM
Compound 4 ended at the assay's limit; the forecaster's own chance of this, stated with the estimate: 2%; middle value at least 12-fold (1.09 log units) from the limit.
By their numbers in this assay, from the lowest: compound 1; then compound 2; then compound 3. At a limit, above all of these: compound 4.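

In this assay, compound 4 gives > 100 nM, which is a limit of the assay and not a number. Putting 1H-pyrrol-3-yl in place of furan-2-yl keeps the count of 5 heavy atoms and the single hetero atom but adds a hydrogen-bond donor, and it gives an at least 10-fold higher number from compound 3 to compound 4 (1.03 log units; beyond the scatter), so this position separates two five-membered aromatic rings that look alike on those counts. For the compounds shown here, the other comparisons, an at least 24-fold higher number from compound 2 to compound 4 (1.39 log units; beyond the scatter) and an at least 150-fold higher number from compound 1 to compound 4 (2.20 log units; beyond the scatter), show that the group on this carbonyl carbon can move the result further than the earlier compounds revealed.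

Furan-2-yl and 1H-pyrrol-3-yl differ in both the hetero atom and the ring position named, so these compounds cannot say which difference matters. Furan-3-yl, 1H-pyrrol-2-yl and 1-methyl-1H-pyrrol-3-yl would each bear on that open question.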